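A few compounds are considered here, and "the series" means these few. Any claim that something is new, unique, unknown or untested is made for them only; others in the source may bear on it.

This study follows a small set of compounds tested in a functional assay on cells (T-cell, Homo sapiens) for inhibition; on this read-out lower numbers stand for stronger inhibition and higher numbers for weaker inhibition. Compound 1 `COc1ccc(-c2cnc3nc(N)nc(NC(C)C)c3n2)cc1OC` gives 600 nM in this assay. Compound 2 `COc1ccc(-c2cnc3nc(N)nc(N4CCN(C(=O)c5ccccc5)CC4)c3n2)cc1OC` gives 400 nM in this assay, the lowest of the two numbers, with compound 1 nearest; the gap between them lies within the scatter, so the two cannot be told apart. Compound 3 `CCOc1nc(N)nc2ncc(-c3ccc(F)c(F)c3)nc12` shows only > 10000 nM, which is a limit of the assay and not a number (the limit of > 10000 nM in this assay, at which 1 of the 3 values shown sits). Compound 4 `COc1ccc(-c2cnc3nc(N)nc(N4CCN(Cc5ccc(C(C)(C)C)cc5)CC4)c3n2)cc1OC` has not yet been measured; it differs from compound 2 by 4-(tert-butyl)benzyl in place of benzoyl on an amine nitrogen in a ring. With no measured step of this kind among these compounds, the change from compound 2 to compound 4 is expected to stay within the scatter a 1.3-fold higher number from compound 2 to compound 4 (0.10 log units; within the scatter). Compound 4 is therefore estimated at 500 nM, from 120 nM to 2500 nM.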

Compound 4, half-maximal inhibitory concentration: 4300 nM
For compound 4 the middle estimate is 8.6-fold (0.93 log units) below the measured one; measured number outside the range, above it.
By their numbers in this assay, from the lowest: compounds 2 and 1 (each within the scatter of the next); then compound 4. At a limit, above all of these: compound 3.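

The group on this ring nitrogen clearly matters: in this assay, 4-(tert-butyl)benzyl in place of benzoyl gives an 11-fold higher number from compound 2 to compound 4 (1.03 log units; beyond the scatter). The swap removes the carbonyl and adds the tert-butyl at once, so this one step cannot show which of the two changes carries the loss. Nothing measured here points to a cause for the step.

On these data alone, it remains open whether a plain benzyl group or a 4-(tert-butyl)benzoyl group on this nitrogen would read like benzoyl or like 4-(tert-butyl)benzyl.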